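This account rests on a few compounds, and the source may have more. Where it says the series, first, only, none or still open, it means among the compounds named here.

In a functional assay on A2780 cells (Homo sapiens) for inhibition, read by sulforhodamine B assay (a lower number here means a stronger inhibitor of growth, a higher number a weaker inhibitor of growth), compound 2 (`COc1ccc(-c2ccc(-c3ccc(-c4nc5cc(C)ccc5[nH]4)cc3)cc2)cc1OC`) gives 2130 nM and shares the low end of the numbers with compound 1 (`Cc1ccc2[nH]c(-c3ccc(-c4ccc(-c5ccc(N(C)C)cc5)cc4)cc3)nc2c1`), which stands level with it (2210 nM). Compound 3 (`COc1ccc(-c2ccc(-c3ccc(-c4nc5ccccc5[nH]4)cc3)cc2)cc1OC`) lies well higher (21600 nM). Within the data shown here, the next compound to consider, compound 4 (`Cc1ccc2[nH]c(-c3ccc(-c4ccc(-c5ccc(F)cc5)cc4)cc3)nc2c1`), has no measurement yet. It keeps the methyl of compound 2 and differs in one group (4-fluorophenyl in place of 3,4-dimethoxyphenyl on an aromatic carbon), with 4-fluorophenyl in place of 3,4-dimethoxyphenyl on an aromatic carbon, para to a large group.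

Among the measured compounds shown here, two measured steps bear on this change. The closer guide is a swap of a group at this same place (a 1.0-fold lower number from compound 1 to compound 2 (0.02 log units; within the scatter)), and it left the number unchanged. The other step (a 10-fold higher number from compound 2 to compound 3 (1.01 log units; beyond the scatter)) is large, but it concerns the methyl, which compound 4 retains. For the measured compounds named here, no measured compound carries 4-fluorophenyl, so the guide is indirect and the range must stay wide. The expected step (a 1.2-fold higher number from compound 2 to compound 4 (0.07 log units; within the scatter)) is therefore none beyond the scatter. For compound 4 the estimated value is about 2500 nM with an expected range from 900 nM to 7000 nM in this measurement.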

Compound 4, concentration for 50% growth inhibition: 24600 nM
Beside the measured number, compound 4's estimate is 9.8-fold (0.99 log units) below it, and the stated range ends below it.
By their numbers in this assay, from the lowest: compounds 2 and 1 (each within the scatter of the next); then compounds 3 and 4 (each within the scatter of the next).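

In this assay, the exchange of 3,4-dimethoxyphenyl for 4-fluorophenyl gives a 12-fold higher number from compound 2 to compound 4 (1.06 log units; beyond the scatter), and the matching exchange of dimethylamino for fluoro gives an 11-fold higher number from compound 1 to compound 4 (1.05 log units; beyond the scatter). The earlier swap at this place had left the number unchanged, so that result did not show that the place accepts any group: among these three compounds, the two with dimethylamino or 3,4-dimethoxyphenyl stand level, and only the one with 4-fluorophenyl departs. No measurement given here accounts for this difference.

As far as these compounds go, it remains open whether the higher number goes with the fluoro group itself or with the loss of the dimethylamino and methoxy groups, a question that a plain phenyl, 4-methoxyphenyl or 4-chlorophenyl at this place could help to settle. From the compounds shown here alone, it is also open how the methyl on the core would count in a compound carrying 4-fluorophenyl.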